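Trimming the Ring Methyl from Compound 1

The source may report more compounds than this note shows. Statements on the series, on what has been measured and on what is new or still open speak of the compounds shown alone.

For the measured compounds named here, compound 1 `CC1CCN(c2c(S(=O)(=O)c3ccccc3)cnc3ccccc23)CC1` gives 108 nM in an assay on isolated protein for displacement of a labelled ligand from metabotropic glutamate receptor 5 (Homo sapiens), with a stated time of 60 min (on this read-out higher numbers stand for weaker inhibition and lower numbers for stronger inhibition), the highest of the three numbers measured so far. Compound 2 `CC1CCN(c2c(S(=O)(=O)c3ccc(Cl)c(Cl)c3)cnc3ccc(Cl)cc23)CC1` gives 55.6 nM in this assay, a gap that lies within the scatter of compound 1, while compound 3 `N#Cc1cc(F)cc(S(=O)(=O)c2cnc3cc(Cl)ccc3c2N2CCC(CO)CC2)c1` gives 24.1 nM in this assay, a gap beyond the scatter. Compound 4 `O=S(=O)(c1ccccc1)c1cnc2ccccc2c1N1CCCCC1` has not yet been measured. It differs from compound 1 by hydrogen in place of methyl on a saturated ring carbon. Going by the values given here, no measured pair shows this change, so the step from compound 1 to compound 4 in this assay is expected to be a 1.5-fold higher number from compound 1 to compound 4 (0.17 log units; within the scatter), a small rise in the number that may not reach beyond the scatter. Compound 4 is therefore estimated at 160 nM in this assay, with a range from 60 nM to 450 nM.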

Compound 4, inhibition constant: 307 nM
The estimate for compound 4 lay 1.9-fold (0.28 log units) below the measured number, within the range that was stated.
By their numbers in this assay, from the lowest: compound 3; then compounds 2 and 1 (each within the scatter of the next); then compound 4.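

The step from 4-methylpiperidin-1-yl to piperidin-1-yl gives a 2.8-fold higher number from compound 1 to compound 4 (0.45 log units; beyond the scatter) in this assay, so the methyl on this saturated ring carbon, three ring bonds from the ring nitrogen, matters beyond the scatter. For the compounds shown here, this pair is the first among the measured compounds to differ in one place, and so the first to isolate this position. The data offer no explanation for the step.

As far as these compounds go, it remains open whether an ethyl group or a primary amine at this carbon would give a lower or higher number, and whether removing the methyl has the same effect on the core of compound 2.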